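The source may hold more compounds than are shown below. What is called first, only, known or untested is meant among the compounds shown, and "the series" means these compounds.

Within the data shown here, compound 2 `CC[C@@H](C)Nc1nc(Cl)nc(N[C@@H](C)c2ccccc2)n1` stands at 9770 nM in an ADME assay on the whole organism for inhibition, with Oryza sativa as the target, with a stated time of 4 days (a lower number here means a stronger inhibitor, a higher number a weaker inhibitor), the higher of the two numbers so far, while compound 1 `C[C@H](Nc1nc(Cl)nc(NC(C)(C)C)n1)c1ccccc1` gives 3310 nM. Compound 3 `CC(C)Nc1nc(Cl)nc(N[C@@H](C)c2ccccc2)n1` differs from compound 2 by hydrogen in place of methyl on a saturated chain carbon, two bonds along the chain from a nitrogen on an aromatic ring. Among the measured compounds shown here, the one measured step that bears on this is a 3.0-fold higher number from compound 1 to compound 2 (0.47 log units; beyond the scatter), which reshaped the same alkyl group on that nitrogen and was modest. Removing one carbon from it is therefore expected to move the number only a little, if at all beyond the scatter. For compound 3 the expected step is a 1.2-fold lower number from compound 2 to compound 3 (0.09 log units; within the scatter). Compound 3 is estimated at 8000 nM, within a range from 3000 nM to 22000 nM.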

Compound 3, half-maximal inhibitory concentration: 23400 nM
For compound 3 the middle estimate is 2.9-fold (0.47 log units) below the measured one, and the stated range ends below it.
By their numbers in this assay, from the lowest: compound 1; then compound 2; then compound 3.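

In this assay, replacing one methyl of the sec-butyl group with hydrogen gives a 2.4-fold higher number from compound 2 to compound 3 (0.38 log units; beyond the scatter) and shows that the loss of this single carbon matters at this position. Isopropyl in place of tert-butyl gives a 7.1-fold higher number from compound 1 to compound 3 (0.85 log units; beyond the scatter) and, among these three compounds, the number rises from tert-butyl through sec-butyl to isopropyl, with none going against that order. No available evidence explains this order.

As far as these compounds go, whether a smaller ethyl or methyl group on that nitrogen would raise the number further remains open. So does the effect of a ring such as cyclopropyl or of a chain ending in an amine.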